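The compounds below may be only part of what the source reports. "The series", "measured", "known", "first", "only" and "open" are said of these compounds alone.

Three compounds share one core and differ only in the group attached to the amide carbonyl. Compound 1 `O=C(Nc1cccc(-c2oc3cc(-c4ccc(F)cc4)ccc3c(=O)c2O)c1)c1ccc(F)cc1` carries a 4-fluorophenyl there, and in a functional assay on HepG2 cells (Homo sapiens) for antiproliferative activity, read by CCK-8 assay, with a stated time of 72 h (a lower number here means a stronger inhibitor, a higher number a weaker inhibitor), compound 1 gives 9280 nM. Compound 2 `O=C(Nc1cccc(-c2oc3cc(-c4ccc(F)cc4)ccc3c(=O)c2O)c1)c1ccc(Br)cc1` carries a 4-bromophenyl, and in this assay compound 2 gives 13900 nM. Compound 3 `COc1cc(OC)cc(C(=O)Nc2cccc(-c3oc4cc(-c5ccc(F)cc5)ccc4c(=O)c3O)c2)c1` carries a 3,5-dimethoxyphenyl, and in this assay compound 3 gives 23500 nM, the highest of the three numbers; the step of a 1.7-fold higher number from compound 2 to compound 3 (0.23 log units; within the scatter) stays within the scatter, whereas the step of a 2.5-fold higher number from compound 1 to compound 3 (0.40 log units; beyond the scatter) lies beyond it. Compound 4 `N#Cc1ccc(C(=O)Nc2cccc(-c3oc4cc(-c5ccc(F)cc5)ccc4c(=O)c3O)c2)cc1` has not yet been measured. It differs from compound 3 in one place: 4-cyanophenyl in place of 3,5-dimethoxyphenyl on a carbonyl carbon. Within the data shown here, no measured step involves a nitrile, so the bearing of the two measured steps is indirect: a 2.5-fold higher number from compound 1 to compound 3 (0.40 log units; beyond the scatter) and a 1.7-fold higher number from compound 2 to compound 3 (0.23 log units; within the scatter) both replace a 4-substituted phenyl with the 3,5-dimethoxyphenyl and both move the number upward, one modestly and one within the scatter. Compound 4, which returns to a 4-substituted phenyl, is expected to sit near compounds 1 and 2 rather than above compound 3. The expected step is therefore a 2.0-fold lower number from compound 3 to compound 4 (0.29 log units; within the scatter), a downward move of modest size at most. In this assay compound 4 is estimated at 12000 nM, with a range from 5000 nM to 30000 nM.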

Compound 4, half-maximal inhibitory concentration: 7110 nM
The estimate for compound 4 lay 1.7-fold (0.23 log units) above the measured number; low and high end bracket the measured number.
By their numbers in this assay, from the lowest: compounds 4, 1, 2 and 3 (each within the scatter of the next, the first and the last beyond it).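

In this assay, the change to 4-cyanophenyl on the carbonyl carbon gives a 3.3-fold lower number from compound 3 to compound 4 (0.52 log units; beyond the scatter) and so adds a second 4-substituted phenyl that stands apart from the 3,5-dimethoxyphenyl of compound 3 beyond the scatter, the first being the 4-fluorophenyl of compound 1, while the 4-bromophenyl of compound 2 goes against this pattern by remaining within the scatter of compound 3. The nitrile is not distinguished from either halogen, since a 2.0-fold lower number from compound 2 to compound 4 (0.29 log units; within the scatter) and a 1.3-fold lower number from compound 1 to compound 4 (0.12 log units; within the scatter) both remain within the scatter, and compounds 1, 2 and 4 therefore cannot be put in any order at this position. No measurement given here accounts for any of these differences.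

The compounds shown leave open whether the higher number of compound 3 follows from its methoxy groups as such or from where they stand on the ring, which a 4-methoxyphenyl or an unsubstituted phenyl could help to separate. They also leave open whether a basic amine or a carboxylic acid on this phenyl ring would give a number outside the range seen so far.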